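Purine replaced by a diaminocyanopyrimidine: expected stability

The source may hold more compounds than are shown below. What is called first, only, known or untested is meant among the compounds shown, and "the series" means these compounds.

Compound 2 `C[C@H](Nc1ncnc2[nH]cnc12)c1cc2ccc(F)cn2c(=O)c1-c1ccccc1` holds the highest of the two numbers in an ADME assay on microsomes from liver (Mus musculus), read by LC-MS, using NADPH, with a stated time of 30 min, tested at 1 uM (a lower number here means that less of the compound is left, a higher number that more of the compound is left), giving 94%; compound 1 `C[C@H](Nc1ncnc2[nH]cnc12)c1cc2ccccn2c(=O)c1-c1ccccc1` gives 51%. Going by the values given here, the single measured step, a number 43 percentage points higher from compound 1 to compound 2 (beyond the scatter), concerns a fluoro on an aromatic carbon, which compound 3 keeps. Compound 3 `C[C@H](Nc1nc(N)nc(N)c1C#N)c1cc2ccc(F)cn2c(=O)c1-c1ccccc1` differs from compound 2 by a group of 10 heavy atoms (5 carbon, 5 nitrogen; one six-membered aromatic ring with 2 hetero atoms) in place of a group of 9 heavy atoms (5 carbon, 4 nitrogen; one five-membered aromatic ring with 2 hetero atoms, one six-membered aromatic ring with 2 hetero atoms), on an amine nitrogen. Among the compounds with values here, no measured step bears on that part of the molecule, so the direction of the change is open, and a step in either direction in this assay is possible. Compound 3 is estimated to give 70% in this assay, between 35% and 98%, an expected step of a number 24 percentage points lower from compound 2 to compound 3 (beyond the scatter).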

Compound 3, percent of the compound remaining: 42%
The estimate for compound 3 lay 28 percentage points above the measured number; low and high end bracket the measured number.
By their numbers in this assay, from the lowest: compounds 3 and 1 (each within the scatter of the next); then compound 2.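

In this assay, exchanging the group on the amine nitrogen for 2,6-diamino-5-cyanopyrimidin-4-yl gives a number 52 percentage points lower from compound 2 to compound 3 (beyond the scatter). This shows that the group at this place strongly affects how much compound remains, and that keeping the aromatic fluoro does not preserve the high number of compound 2 once this group is exchanged. Nothing available explains the step.

The compounds shown leave open which part of the new group matters, the nitrile or the amino groups. They also leave open whether a chlorine in place of the nitrile would change the number.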